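A few compounds are considered here, and "the series" means these few. Any claim that something is new, unique, unknown or untested is made for them only; others in the source may bear on it.

Of the compounds shown here, two have been measured in a functional assay on a cell-free system (plasma) with thromboxane A2 receptor (Homo sapiens) as the target; a lower number here means a stronger inhibitor, a higher number a weaker inhibitor. Compound 1 `CCCCCCSC[C@H]1C2CC[C@@H](O2)[C@H]1C/C=C\CCCC(=O)O` gives 83000 nM in this assay. Compound 2 `O=C(O)CCC/C=C\CC1C2CCC(O2)C1CSC/C=C/c1ccccc1` gives 86000 nM, a number that is nominally the higher of the two but lies within the scatter of the result for compound 1, so the two cannot be told apart. Compound 3 `CSCC1C2CCC(O2)C1C/C=C\CCCC(=O)O` is the unmeasured member; relative to compound 2 the change is hydrogen in place of 2-phenylethenyl on a saturated chain carbon bound to a sulfur. For the measured compounds named here, no step between measured compounds exists to calibrate this particular cut, and both measured compounds are only weak inhibitors. With the side chain reduced to methyl, compound 3 is expected to lose some further potency, so the step from compound 2 to compound 3 is estimated at a 2.3-fold higher number from compound 2 to compound 3 (0.37 log units; beyond the scatter), most likely beyond the scatter but modest. The expected value for compound 3 in this assay is 200000 nM, with a range from 80000 nM to 600000 nM.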

Compound 3, half-maximal inhibitory concentration: 38000 nM
The estimate for compound 3 lay 5.3-fold (0.72 log units) above the measured number, and the stated range ends above it.
By their numbers in this assay, from the lowest: compound 3; then compounds 1 and 2 (each within the scatter of the next).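

In this assay the 2-phenylethenyl group on a saturated chain carbon bound to a sulfur proves dispensable: replacing it with hydrogen gives a 2.3-fold lower number from compound 2 to compound 3 (0.35 log units; beyond the scatter) and so a modest gain, not a loss. This position therefore accepts the removal of an aromatic ring and a double bond together, although compound 3 at 38000 nM is still only a weak inhibitor. Nothing shown here accounts for the direction of this step.

The compounds shown leave open whether the gain comes from losing the phenyl ring or the double bond, which a saturated 2-phenylethyl group could help to separate. They also leave open how an ethyl group, or a short chain ending in an amine or a carboxylic acid, would fare at this position.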